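The compounds below may be only part of what the source reports. "The series", "measured", "known", "first", "only" and "open" are said of these compounds alone.

Measured in an ADME assay on the whole organism (plasma, strain 129/SvEvBrd x C57BL/6) for pharmacokinetics, with Mus musculus as the target, at a dose of 10 mg/kg by the oral route; on this read-out lower numbers stand for lower exposure and higher numbers for higher exposure at the dose given:
- compound 1 `CC(=O)c1ncc([C@@H](O)[C@H](O)[C@H](O)CO)s1`: 668 ng.h/mL
- compound 2 `OC[C@@H](O)[C@@H](O)[C@H](O)c1c[nH]c(-c2cocn2)n1`: 868 ng.h/mL

At 868 ng.h/mL, compound 2 lies within the usual scatter of compound 1, which gives 668 ng.h/mL, so the two values cannot be told apart in this assay. Compound 3 `Cn1cnc(-c2nc([C@@H](O)[C@H](O)[C@H](O)CO)c[nH]2)c1`, not yet measured, departs from compound 2 at one place: 1-methyl-1H-imidazol-4-yl in place of 1,3-oxazol-4-yl on an aromatic carbon, between two ring nitrogen atoms (1-methyl-1H-imidazol-4-yl in place of 1,3-oxazol-4-yl on an aromatic carbon). For the measured compounds named here, the two measured compounds do not differ at one place only, so no measured step shows what this exchange does. No step beyond the scatter is therefore expected in this assay, and the estimated change is a 1.3-fold lower number from compound 2 to compound 3 (0.13 log units; within the scatter), though with wide uncertainty and no firm direction. For compound 3 the expected value is 650 ng.h/mL, with an estimated range from 220 ng.h/mL to 1900 ng.h/mL.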

Compound 3, area under the concentration-time curve: 698 ng.h/mL
The estimate for compound 3 lay 1.1-fold (0.03 log units) below the measured number, within the range that was stated.
By their numbers in this assay, from the lowest: compounds 1, 3 and 2 (each within the scatter of the next).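

In this assay, putting 1-methyl-1H-imidazol-4-yl in place of 1,3-oxazol-4-yl on an aromatic carbon, between two ring nitrogen atoms, gives a 1.2-fold lower number from compound 2 to compound 3 (0.09 log units; within the scatter). For the compounds shown here, this is the only one-place step in the set, and it shows that this exchange at this position leaves the exposure indistinguishable at the oral dose given, so the two groups cannot be told apart on this read-out. No supporting data bear on why the two compounds read alike.

On these data alone, whether a different kind of group at this position, such as a primary amine, a carboxylic acid or a longer alkyl chain, would shift the exposure beyond the scatter remains open. Also open, as far as these compounds go, is what would follow from changing the hydroxyl-bearing chain that compound 2 and compound 3 share, for instance by replacing a hydroxyl group with a methoxy group.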